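Adding a cyclopropylsulfonyl group to the pyrrolidine of compound 2

The compounds below may be only part of what the source reports. "The series", "measured", "known", "first", "only" and "open" are said of these compounds alone.

Results in a functional assay on HCC827 cells (Homo sapiens) for antiproliferative activity, read by MTT assay, with a stated time of 72 h; a higher number here means a weaker inhibitor, a lower number a stronger inhibitor:
- Compound 1 `CN1CCN(c2ccc(Nc3ncc4nc(Nc5ccc(F)cc5)n([C@@H]5CCCN(C(=O)CO)C5)c4n3)cc2)CC1` gives 66 nM
- Compound 2 `CN1CCN(c2ccc(Nc3ncc4nc(Nc5ccc(F)cc5)n([C@@H]5CCNC5)c4n3)cc2)CC1` gives 300 nM

Compound 2 has the higher, and so weaker, of these two numbers. Compound 3 `CN1CCN(c2ccc(Nc3ncc4nc(Nc5ccc(F)cc5)n([C@H]5CCN(S(=O)(=O)C6CC6)C5)c4n3)cc2)CC1` is still unmeasured and differs from it as follows: 1-(cyclopropylsulfonyl)pyrrolidin-3-yl in place of pyrrolidin-3-yl on an aromatic nitrogen. For the measured compounds named here, one measured step bears on this change: a 4.5-fold higher number from compound 1 to compound 2 (0.66 log units; beyond the scatter). Like compound 1, compound 3 carries a group on the nitrogen of its saturated ring, though a sulfonyl rather than a carbonyl. A single pair is thin evidence, but a smaller step towards a lower number is expected in this assay. The expected change is a 3.0-fold lower number from compound 2 to compound 3 (0.48 log units; beyond the scatter). Compound 3 is estimated at 100 nM, within an expected range of 35 nM to 280 nM.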

Compound 3, half-maximal inhibitory concentration: 7.5 nM
The estimate for compound 3 lay 13-fold (1.12 log units) above the measured number, outside the stated range (below it).
By their numbers in this assay, from the lowest: compound 3; then compound 1; then compound 2.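

In this assay the cyclopropylsulfonyl group on the pyrrolidine nitrogen brings a large gain (a 40-fold lower number from compound 2 to compound 3 (1.60 log units; beyond the scatter)), so this position tolerates a much bigger group and responds strongly to it. Compound 3 also beats the hydroxyacetyl-type piperidine (an 8.8-fold lower number from compound 1 to compound 3 (0.94 log units; beyond the scatter)), so which group and ring sit here matters, not merely whether the ring nitrogen is substituted. No measurement here accounts for the gain.

Open, from the compounds shown here alone, is whether the cyclopropyl or the sulfonyl drives it: a methylsulfonyl or phenylsulfonyl group on this pyrrolidine would test that.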